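An aryl swap at the saturated ring carbon

The source may hold more compounds than are shown below. What is called first, only, known or untested is meant among the compounds shown, and "the series" means these compounds.

Of the compounds shown here, two have been measured in a functional assay on BGC-823 cells (Homo sapiens) for antiproliferative activity, read by MTT assay, tested at 1 uM; on this read-out lower numbers stand for a weaker effect and higher numbers for a stronger effect at the one concentration tested. Compound 1 `COc1cc(C2=NN(C(C)=O)C(c3ccc(F)cc3)O2)cc(OC)c1OC` gives -0.4% in this assay, while compound 2 `COc1cc(C2=NN(C(C)=O)C(c3ccccc3F)O2)cc(OC)c1OC` gives 29.6%. For the measured compounds named here, the single step between them, a number 30 percentage points higher from compound 1 to compound 2 (beyond the scatter), is the only measured step on record, and it places compound 2 at the higher of the two numbers, with compound 1 lower by a step that lies beyond the scatter.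

Compound 3 `COc1cc(C2=NN(C(C)=O)C(c3cccc(C(F)(F)F)c3)O2)cc(OC)c1OC` has not been measured. It differs from compound 2 in one place: 3-(trifluoromethyl)phenyl in place of 2-fluorophenyl on a saturated ring carbon. Going by the values given here, the measured step from compound 1 to compound 2 concerns a move of a fluorine on this same aryl group and shows that the group at this saturated ring carbon can shift the read-out by a modest amount; it does not, however, cover a 3-(trifluoromethyl)phenyl group, so no direct precedent exists. A step of modest size in either direction is therefore plausible, and the expectation is that the number moves by a number 14.6 percentage points lower from compound 2 to compound 3 (beyond the scatter). On that basis compound 3 is estimated to give 15% in this assay, within the range -10% to 40%.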

Compound 3, a percentage reported as inhibition, at one concentration (the size of the read-out at that concentration, not a potency): 27.9%
Estimate against measurement, compound 3: 12.9 percentage points below; low and high end bracket the measured number.
By their numbers in this assay, from the lowest: compound 1; then compounds 3 and 2 (each within the scatter of the next).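

Compound 3 brings a second, quite different aryl group to this saturated ring carbon, and in this assay the result is a number 1.7 percentage points lower from compound 2 to compound 3 (within the scatter): exchanging 2-fluorophenyl for 3-(trifluoromethyl)phenyl, with its larger heavy-atom count and two further fluorines, leaves the read-out indistinguishable. For the compounds shown here, the other new step, a number 28.3 percentage points higher from compound 1 to compound 3 (beyond the scatter), shows that compound 1 now stands apart from both other compounds, which the single earlier step could not show, although three compounds are too few to make this a rule for the position. Nothing available explains why the 4-fluorophenyl compound gives so little effect at this concentration, or why the other two aryl groups match.

The compounds shown leave open whether the position would keep this level of effect with an aryl group carrying an amine or a carboxylic acid, or with a longer chain in place of the aryl group. They also leave open how these compounds compare in potency, since each number describes the size of the effect at a single concentration.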